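Piperazine amide in place of methyl on the cyclopentylmethyl series

A few compounds are considered here, and "the series" means these few. Any claim that something is new, unique, unknown or untested is made for them only; others in the source may bear on it.

Measured so far:
- compound 1, `CNc1ncc2c(-c3ccc(N4CCN(C(=O)C(C)(C)C)CC4)nc3)nn(Cc3cn(Cc4ccccc4)nn3)c2n1`: > 10000 nM
- compound 2, `CNc1ncc2c(-c3ccc(N4CCN(C)CC4)nc3)nn(CC3CCCC3)c2n1`: 3670 nM

Notes. Within the data shown here, compound 2, `CNc1ncc2c(-c3ccc(N4CCN(C)CC4)nc3)nn(CC3CCCC3)c2n1`, is the only compound with a numerical result in an assay for inhibition of tyrosine-protein kinase receptor TYRO3 (Homo sapiens), read by 33P incorporation, in the presence of a further agent that is not named here (a higher number here means a weaker inhibitor, a lower number a stronger inhibitor), where compound 2 gives 3670 nM. For compound 1, `CNc1ncc2c(-c3ccc(N4CCN(C(=O)C(C)(C)C)CC4)nc3)nn(Cc3cn(Cc4ccccc4)nn3)c2n1`, this assay reports only a limit, > 10000 nM, which is not a number; it sits at the limit of > 10000 nM in this assay, at which 1 of the 2 values shown sits. Among the measured compounds shown here, compound 1 and compound 2 differ in two places at once, so their pair gives no single step.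

Compound 3, `CNc1ncc2c(-c3ccc(N4CCN(C(=O)C(C)(C)C)CC4)nc3)nn(CC3CCCC3)c2n1`, is not yet measured. Relative to compound 2 the change is (tert-butyl)carbonyl in place of methyl on an amine nitrogen in a ring. For the measured compounds named here, no measured pair isolates this change. Compound 1, which also carries the (tert-butyl)carbonyl group, returns only a limit, so the expectation is a loss of potency rather than a gain, with a fair chance that only a limit is reported. Compound 3 is estimated at 7000 nM, between 2500 nM and 20000 nM, a step of a 1.9-fold higher number from compound 2 to compound 3 (0.28 log units; within the scatter) expected beyond the usual scatter.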

Compound 3, half-maximal inhibitory concentration: > 10000 nM
Compound 3 ended at the assay's limit (the forecaster's own chance of this, stated with the estimate: 35%); middle value at least 1.4-fold (0.15 log units) away from the limit.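

In this assay, among these compounds, (tert-butyl)carbonyl in place of methyl on the ring amine nitrogen gives an at least 2.7-fold higher number from compound 2 to compound 3 (0.43 log units; beyond the scatter), the first reading of this change in a single place, and it shows that this position does not tolerate the exchange on the cyclopentylmethyl series. As far as these compounds go, compound 3 gives > 10000 nM, which is a limit of the assay and not a number, so the full size of the loss stays unknown: the limit of > 10000 nM in this assay, at which 2 of the 3 values shown sit. The step between compound 1 and compound 3 cannot be read, as both values are limits, so nothing follows about cyclopentyl in place of 1-benzyl-1H-1,2,3-triazol-4-yl.

The compounds shown do not separate the carbonyl from the tert-butyl group. Open, from the compounds shown here alone, is how an acetyl group, an ethyl group or a free ring amine at this nitrogen would read in this assay against compound 2.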